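From cyclopropyl to 1-methylcyclopropyl on the shared core

The source may hold more compounds than are shown below. What is called first, only, known or untested is meant among the compounds shown, and "the series" means these compounds.

In a physicochemical assay for solubility, using the shake flask method, in phosphate buffer, measured as kinetic solubility, with a stated time of 20 h, at pH 6.5 (a higher number here means a more soluble compound, a lower number a less soluble compound), compound 3 `FC(F)(F)c1ccc(Nc2cc3[nH]c(C4CC4)nc3cn2)nc1` gives < 5000 nM as a limit of the assay and not as a number. Its place therefore rests on the limit of < 5000 nM in this assay, at which 1 of the 3 values shown sits, and not on a measured reading. In this assay compound 1 `FC1(F)CCC(c2nc3cnc(Nc4ccc(C(F)(F)F)cn4)cc3[nH]2)C1` gives 120000 nM and compound 2 `FC(F)(F)c1ccc(Nc2cc3[nH]c(C4CCOCC4)nc3cn2)nc1` gives 155000 nM on the same scale. The step between these two is a 1.3-fold higher number from compound 1 to compound 2 (0.11 log units; within the scatter) and shows no real difference. Putting cyclopropyl on the aromatic carbon gives an at least 24-fold lower number from compound 1 to compound 3 (1.38 log units; beyond the scatter) and also an at least 31-fold lower number from compound 2 to compound 3 (1.49 log units; beyond the scatter) in this assay as the two large steps of the set.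

Compound 4 `CC1(c2nc3cnc(Nc4ccc(C(F)(F)F)cn4)cc3[nH]2)CC1` keeps the ring of compound 3 and takes methyl in place of hydrogen on a saturated ring carbon. The difference is methyl in place of hydrogen on a saturated ring carbon and it turns cyclopropyl into 1-methylcyclopropyl. Within the data shown here, no measured step makes this change. The two large steps replace the whole group on the aromatic carbon, so they bear on it only loosely, though both leave compound 3 as the low end of the set. A modest rise is expected, estimated as an at least 1.6-fold higher number from compound 3 to compound 4 (0.20 log units; that floor lies within the scatter) and well short of those large steps. Compound 4 is estimated at 8000 nM with 2000 nM to 40000 nM as its expected range.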

Compound 4, solubility: 188000 nM
For compound 4 the middle estimate is 24-fold (1.37 log units) below the measured one; the measured number lies above the stated range.
By their numbers in this assay, from the lowest: compounds 1, 2 and 4 (each within the scatter of the next). At a limit, below all of these: compound 3.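

In this assay a single methyl on a saturated ring carbon of the three-membered ring lifts the compound out of the low end of the set (an at least 37-fold higher number from compound 3 to compound 4 (1.57 log units; beyond the scatter)), so a change of one heavy atom at this place gives a large step, as the earlier replacements of the whole group on the aromatic carbon did. The new group also joins the two larger groups (a 1.2-fold higher number from compound 2 to compound 4 (0.08 log units; within the scatter) and a 1.6-fold higher number from compound 1 to compound 4 (0.19 log units; within the scatter)), so that 1-methylcyclopropyl, oxan-4-yl and 3,3-difluorocyclopentyl cannot be told apart here and only unsubstituted cyclopropyl stands apart. The value of compound 3 (< 5000 nM) is a limit of the assay and not a number, so the step up from it has a floor and no measured size: the limit of < 5000 nM in this assay, at which 1 of the 4 values shown sits.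

The compounds shown leave open whether the same rise would come with an ethyl, a hydroxymethyl or a single fluorine on that ring carbon, or with a methyl on another carbon of the three-membered ring. They also leave open whether a plain cyclobutyl on the aromatic carbon would stay at the low end with cyclopropyl or join the other groups.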